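The source may report more compounds than this note shows. Statements on the series, on what has been measured and on what is new or still open speak of the compounds shown alone.

Compound 3 `CCCCc1ccc(NC(=O)N[C@H](C)c2ccccc2)cc1` stands lowest of the three measured compounds in an ADME assay on the whole organism with Oryza sativa as the target, tested at 1 uM (a lower number here means a stronger effect, a higher number a weaker effect of the compound at the concentration tested), giving 32%. Within the data shown here, compound 1 `CCCc1ccc(NC(=O)N[C@@H](C)c2ccccc2)cc1` gives 76% and compound 2 `C[C@H](NC(=O)Nc1ccc(C(C)(C)C)cc1)c1ccccc1` gives 88%; the only step between neighbours, a number 12 percentage points higher from compound 1 to compound 2 (beyond the scatter), concerns the group on the aromatic carbon and not configuration. Compound 4 `CCCCc1ccc(NC(=O)N[C@@H](C)c2ccccc2)cc1` differs from compound 3 as follows: the two compounds have the same atoms and bonds and differ only in configuration as drawn: 1 of 1 stereo elements differ; a stereocentre at a saturated chain carbon is drawn R in compound 3 and S in compound 4. Among the measured compounds shown here, no measured step alters configuration alone; compound 1 and compound 3 differ in both chain and drawn configuration, so their gap cannot be assigned to either. The writer therefore expects for compound 4 a step of uncertain direction, a number 18 percentage points higher from compound 3 to compound 4 (beyond the scatter), and estimates compound 4 in this assay at 50%, within a range from 25% to 80%.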

Compound 4, a percentage reported as activity, at one concentration (the size of the read-out at that concentration, not a potency): 72%
The estimate for compound 4 lay 22 percentage points below the measured number, within the range that was stated.
By their numbers in this assay, from the lowest: compound 3; then compounds 4 and 1 (each within the scatter of the next); then compound 2.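

Inverting the drawn stereocentre at the saturated chain carbon gives, in this assay, a number 40 percentage points higher from compound 3 to compound 4 (beyond the scatter), a large step that can be assigned to configuration alone: the fact that compounds 3 and 4 differ only in the configuration as drawn. With that configuration kept, methyl in place of hydrogen on a saturated chain carbon gives a number 4 percentage points lower from compound 1 to compound 4 (within the scatter), so propyl and butyl are not told apart here. Butyl in place of tert-butyl gives a number 16 percentage points lower from compound 2 to compound 4 (beyond the scatter), so the shape of the chain still counts. The compounds shown leave open whether configuration matters as much with propyl or tert-butyl, and how a longer chain or an amine on the aromatic carbon would read.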